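Replacing cyano with difluoromethyl: what to expect

A few compounds are considered here, and "the series" means these few. Any claim that something is new, unique, unknown or untested is made for them only; others in the source may bear on it.

In an in vitro ADME assay on microsomes from liver (Simiiformes) (a lower number here means that the compound disappears faster, a higher number that the compound lasts longer), compound 3 (`Cc1cc(CCCOc2c(C)cc(-c3noc(C#N)n3)cc2C)on1`) gives 0.283 h and compound 1 (`Cc1cc(CCCOc2c(C)cc(-c3noc(CC(F)(F)F)n3)cc2C)on1`) gives 0.533 h, two values within the scatter of each other. Compound 2 (`Cc1cc(CCCOc2c(C)cc(-c3noc(C(N)=O)n3)cc2C)on1`) stands clearly apart at 2.3 h, with an 8.1-fold lower number from compound 2 to compound 3 (0.91 log units; beyond the scatter).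

The next structure, compound 4 (`Cc1cc(CCCOc2c(C)cc(-c3noc(C(F)F)n3)cc2C)on1`), keeps the shared core and changes one group: difluoromethyl in place of cyano on an aromatic carbon, (difluoromethyl in place of cyano on an aromatic carbon). For the measured compounds named here, no measured pair makes this exact swap, but two steps bear on it. Compound 1 also carries a fluorinated group, 2,2,2-trifluoroethyl, and swapping that group for cyano gives a 1.9-fold lower number from compound 1 to compound 3 (0.27 log units; within the scatter). The large shifts involve carbamoyl, as in a 4.3-fold higher number from compound 1 to compound 2 (0.64 log units; beyond the scatter), and compound 4 has no carbamoyl. A value near compound 1 is therefore more likely than one near compound 2, and no step beyond the scatter is expected. The expected step is a 1.8-fold higher number from compound 3 to compound 4 (0.25 log units; within the scatter). For compound 4 the estimate in this assay is 0.5 h, with an expected range of 0.2 h to 1.3 h.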

Compound 4, half-life: 1.42 h
For compound 4 the middle estimate is 2.8-fold (0.45 log units) below the measured one; the whole stated range lies below it.
By their numbers in this assay, from the lowest: compounds 3 and 1 (each within the scatter of the next); then compounds 4 and 2 (each within the scatter of the next).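

In this assay, this position does not divide simply into fluorinated groups on one side and carbamoyl on the other: swapping cyano for difluoromethyl is a clear step (a 5.0-fold higher number from compound 3 to compound 4 (0.70 log units; beyond the scatter)), and difluoromethyl also parts from 2,2,2-trifluoroethyl (a 2.7-fold higher number from compound 1 to compound 4 (0.43 log units; beyond the scatter)), so the two fluorinated groups do not read alike. Difluoromethyl instead falls within the scatter of carbamoyl (a 1.6-fold lower number from compound 2 to compound 4 (0.21 log units; within the scatter)), which shows that a number in this range at this position is not tied to carbamoyl. No measurement shown here accounts for these differences.

Still open is where trifluoromethyl or monofluoromethyl, placed directly on the same ring carbon, would fall among these compounds. As far as these compounds go, an amine or a carboxylic acid at this position is equally open, as is whether difluoromethyl would give the same step on a different core.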